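Swapping methoxy for nitro on compound 2

This account rests on a few compounds, and the source may have more. Where it says the series, first, only, none or still open, it means among the compounds named here.

Compound 1 `C/C(=C\c1ccccc1)C(=O)/C=C/c1ccc([N+](=O)[O-])cc1`: 26000 nM
Compound 2 `COc1ccc(/C=C/C(=O)/C(C)=C/c2ccc(OC)cc2)cc1`: 34100 nM

Both values come from an ADME assay on J774.A1 cells (Mus musculus) for cytotoxicity, read by MTT assay, with a stated time of 48 h; on this read-out higher numbers stand for lower toxicity in this test and lower numbers for higher toxicity in this test. Compound 2 stands at 34100 nM and compound 1 at 26000 nM, and these two numbers lie within the usual scatter of each other. Compound 3 `COc1ccc(/C=C(\C)C(=O)/C=C/c2ccc([N+](=O)[O-])cc2)cc1` has not yet been measured. It differs from compound 2 by one change, nitro in place of methoxy on an aromatic carbon, para to a large group: nitro in place of methoxy on an aromatic carbon. Within the data shown here, no measured pair shows this change alone. Compound 1 also carries a nitro group, and its 26000 nM sits within the scatter of compound 2, so no step beyond the scatter is expected in this assay, in either direction. The expected change is a 1.2-fold lower number from compound 2 to compound 3 (0.09 log units; within the scatter). For compound 3 the estimated value is 28000 nM, with an expected range from 13000 nM to 60000 nM.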

Compound 3, half-maximal cytotoxic concentration: 30000 nM
Estimate against measurement, compound 3: 1.1-fold (0.03 log units) below; the range from low to high includes it.
By their numbers in this assay, from the lowest: compounds 1, 3 and 2 (each within the scatter of the next).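

In this assay the swap of nitro for methoxy on an aromatic carbon, para to a large group, now has a direct reading: a 1.1-fold lower number from compound 2 to compound 3 (0.06 log units; within the scatter) and so no step beyond the scatter. Methoxy in place of hydrogen on an aromatic carbon gives a 1.2-fold higher number from compound 1 to compound 3 (0.06 log units; within the scatter) and likewise stays within the scatter, so neither single change separates these compounds in this read-out. Nothing measured here bears on the reason for these results.

The compounds shown carry only hydrogen, methoxy or nitro at these aromatic carbons, so the effect of an amine or a carboxylic acid there in this assay remains open. Going by these compounds, whether any change at these places could produce a step beyond the scatter also remains open.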